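A second hydroxyphenyl on the shared core

The source may report more compounds than this note shows. Statements on the series, on what has been measured and on what is new or still open speak of the compounds shown alone.

Compound 1 `Oc1cccc(-c2cc(-c3ccccc3)cc(-c3cccs3)n2)c1`: 17000 nM
Compound 2 `Oc1cccc(-c2cc(-c3ccccc3)cc(-c3cccc(O)c3)n2)c1`: 13000 nM
Compound 3 `Oc1ccc(-c2cc(-c3ccccc3)cc(-c3cccs3)n2)cc1`: 1700 nM

These values come from a functional assay on HeLa cells (Homo sapiens) for cytotoxicity, read by ELISA, with a stated time of 2 days; a higher number here means a weaker inhibitor, a lower number a stronger inhibitor. Compound 3 has the lowest number of the three, clearly apart from the other two. Compound 4 `Oc1ccc(-c2cc(-c3ccccc3)cc(-c3ccc(O)cc3)n2)cc1` differs from it by one swap, 4-hydroxyphenyl in place of thiophen-2-yl on an aromatic carbon. Among the compounds with values here, the closest precedent, with 3-hydroxyphenyl entering instead, is a 1.3-fold lower number from compound 1 to compound 2 (0.12 log units; within the scatter). Changing 3-hydroxyphenyl to 4-hydroxyphenyl gave a larger change, a 10-fold lower number from compound 1 to compound 3 (1.00 log units; beyond the scatter), so that precedent may not carry over exactly. No step beyond the scatter is therefore expected in this assay. The expected step is a 1.3-fold higher number from compound 3 to compound 4 (0.11 log units; within the scatter). Compound 4 is estimated at 2200 nM, with an expected range of 700 nM to 7000 nM.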

Compound 4, half-maximal inhibitory concentration: 3300 nM
Compound 4: the middle estimate sits 1.5-fold (0.18 log units) below what was measured; the measured number falls inside the stated range.
By their numbers in this assay, from the lowest: compounds 3 and 4 (each within the scatter of the next); then compounds 2 and 1 (each within the scatter of the next).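

In this assay, putting 4-hydroxyphenyl in place of thiophen-2-yl on the carbon next to the ring nitrogen gives a 1.9-fold higher number from compound 3 to compound 4 (0.29 log units; within the scatter). The swap of a sulfur-containing five-membered ring for a larger six-membered ring with a hydroxyl group therefore leaves the number within the scatter, not only with the 3-hydroxyphenyl partner but also with a 4-hydroxyphenyl group on the shared core. Nothing available explains this result.

Still open, going by these compounds, is how this position responds to something other than an aromatic ring, such as an amine or a carboxylic acid.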